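Chloro in place of fluoro: compound 3 awaits measurement

The source may report more compounds than this note shows. Statements on the series, on what has been measured and on what is new or still open speak of the compounds shown alone.

Measured so far in an ADME assay on HEK-293T cells (Homo sapiens) for cytotoxicity, read by MTT assay, with a stated time of 24 h; a higher number here means that more compound is tolerated, a lower number that less compound is tolerated:
compound 1 `Cc1ccc(-c2nn(-c3ccccc3)cc2-c2nc3ccccc3n2S(=O)(=O)c2ccccc2)cc1` gives 138000 nM
compound 2 `Cc1ccc(-c2nn(-c3ccccc3)cc2-c2nc3ccccc3n2S(=O)(=O)c2ccc(F)cc2)cc1` gives 128000 nM

Within the data shown here, only two compounds have been measured, so compound 2, at 128000 nM, has a single neighbour. Among the measured compounds shown here, the one measured step between them is a 1.1-fold lower number from compound 1 to compound 2 (0.03 log units; within the scatter), which leaves the pair level with each other.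

The next compound is compound 3 `Cc1ccc(-c2nn(-c3ccccc3)cc2-c2nc3ccccc3n2S(=O)(=O)c2ccc(Cl)cc2)cc1`, which keeps the shared core and alters one atom of compound 2. A 4-fluorophenyl becomes a 4-chlorophenyl, with chloro in place of fluoro on an aromatic carbon, para to a large group (chloro in place of fluoro on an aromatic carbon).

For the measured compounds named here, the one measured step bearing on this change is the replacement at that same aromatic carbon, a 1.1-fold lower number from compound 1 to compound 2 (0.03 log units; within the scatter), and it did not rise above the scatter. Going by the values given here, that is thin evidence, since no chloro compound has yet been measured. Even so, the expected change is small, namely a 1.0-fold lower number from compound 2 to compound 3 (0.01 log units; within the scatter), with no direction expected beyond the scatter in this assay.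

For compound 3 the estimated value is 125000 nM, with an expected range from 75000 nM to 200000 nM.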

Compound 3, half-maximal cytotoxic concentration: 167000 nM
Beside the measured number, compound 3's estimate is 1.3-fold (0.13 log units) below it, and the stated range covers the measured number.
By their numbers in this assay, from the lowest: compounds 2, 1 and 3 (each within the scatter of the next).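

In this assay, the position on an aromatic carbon of a six-membered aromatic ring of carbon only, para to a large group, has now been read with a second halogen: chloro in place of fluoro gives a 1.3-fold higher number from compound 2 to compound 3 (0.12 log units; within the scatter), and chloro in place of hydrogen gives a 1.2-fold higher number from compound 1 to compound 3 (0.08 log units; within the scatter). Compounds 1 and 2 had shown only that fluoro and hydrogen could not be told apart here, whereas compound 3 extends this to chloro, so hydrogen, fluoro and chloro at this carbon all read within the scatter of one another. Nothing available gives a reason for this reading.

The three compounds leave open whether this position stays just as flat with a group other than a halogen on it, such as an amine, a carboxylic acid or a methoxy group, or whether the reading would then move beyond the scatter. They also leave open whether changes elsewhere on the shared core, such as to the methyl group or the sulfonyl link, would move the number in this cell line.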